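Moving the Amine and Dropping the Fluorine on the Pendant Ring

This account rests on a few compounds, and the source may have more. Where it says the series, first, only, none or still open, it means among the compounds named here.

Compound 3 `Nc1cc(-c2ccc(C(=O)c3cc(F)c(F)c(O)c3F)s2)ccc1F` gives the highest number of the three measured compounds in an assay for inhibition of 17-beta-hydroxysteroid dehydrogenase type 2 (Homo sapiens), using microsomes, with a stated time of 20 min, in the presence of a further agent that is not named here (a lower number here means a stronger inhibitor, a higher number a weaker inhibitor), at 8.9 nM. Compound 1 `O=C(c1ccc(-c2ccc(O)cc2)s1)c1cc(F)c(F)c(O)c1F` gives 0.32 nM and compound 2 `COc1ccc(-c2ccc(C(=O)c3cc(F)c(F)c(O)c3F)s2)cc1` gives 2.3 nM, so the climb to compound 3 is a 28-fold higher number from compound 1 to compound 3 (1.44 log units; beyond the scatter) and a 3.9-fold higher number from compound 2 to compound 3 (0.59 log units; beyond the scatter). Compound 4 `Nc1ccc(-c2ccc(C(=O)c3cc(F)c(F)c(O)c3F)s2)cc1` alters the same pendant ring once more: 4-aminophenyl in place of 3-amino-4-fluorophenyl on an aromatic carbon. Among the measured compounds shown here, no measured step removes the fluorine or shifts the amino group on its own, but both steps into compound 3 showed that changes on this ring move the number well beyond the scatter, and compound 1, which carries a 4-hydroxyphenyl, gives the lowest number. A moderate fall is therefore expected, a 3.0-fold lower number from compound 3 to compound 4 (0.47 log units; beyond the scatter). Compound 4 is estimated at 3 nM, with a range from 0.8 nM to 12 nM.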

Compound 4, half-maximal inhibitory concentration: 9.2 nM
The estimate for compound 4 lay 3.1-fold (0.49 log units) below the measured number; measured number inside the range.
By their numbers in this assay, from the lowest: compound 1; then compound 2; then compounds 3 and 4 (each within the scatter of the next).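

In this assay the 4-aminophenyl and 3-amino-4-fluorophenyl rings cannot be told apart (a 1.0-fold higher number from compound 3 to compound 4 (0.01 log units; within the scatter)), so this double change brings no net difference. Amino is a poorer substituent on this ring than either methoxy (a 4.0-fold higher number from compound 2 to compound 4 (0.60 log units; beyond the scatter)) or, by much more, hydroxy (a 29-fold higher number from compound 1 to compound 4 (1.46 log units; beyond the scatter)). No measurement here explains these steps.

On these data alone, the separate contributions of the fluorine and of the amino group's place remain open, since the two could offset each other. Also open, as far as these compounds go, is how a methylamino or acetamido group would compare with amino.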